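Methyl for trifluoromethyl: a parallel step on a second core

The compounds below may be only part of what the source reports. "The series", "measured", "known", "first", "only" and "open" are said of these compounds alone.

Measured so far in a functional assay on MGC-803 cells (Homo sapiens) for cytotoxicity, read by MTT assay, with a stated time of 72 h; a lower number here means a stronger inhibitor, a higher number a weaker inhibitor:
compound 1, `COc1cc2ncnc(NNC(=S)NC(=O)c3ccc(C)cc3)c2cc1OC`, gives 19700 nM
compound 2, `COc1cc2ncnc(NNC(=S)NC(=O)c3ccc(C(F)(F)F)cc3)c2cc1OC`, gives 9280 nM
compound 3, `O=C(NC(=S)NNc1ncnc2ccccc12)c1ccc(C(F)(F)F)cc1`, gives 10600 nM

Compound 1 and compound 2 share one core; compound 3 carries a second core with the same acyl thiourea hydrazine side. The difference between the two cores is not broken down here. Within the first core the only change is methyl in place of trifluoromethyl on an aromatic carbon, and the step it made is a 2.1-fold higher number from compound 2 to compound 1 (0.33 log units; beyond the scatter), a modest shift that nonetheless lies beyond the scatter. Compound 3 and compound 2 stand within the scatter of each other in this assay, so the two cores, each with the trifluoromethyl group in place, cannot be told apart on these numbers.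

Compound 4, `Cc1ccc(C(=O)NC(=S)NNc2ncnc3ccccc23)cc1`, is not yet measured. It relates to compound 3 as compound 1 relates to compound 2: the change is methyl in place of trifluoromethyl on an aromatic carbon, the same change as before, at a place described in identical terms. Within the data shown here, the expectation is therefore that the same step repeats on the second core, with compound 4 showing a step of a 2.1-fold higher number from compound 3 to compound 4 (0.32 log units; beyond the scatter) from compound 3, because the single comparable precedent is a 2.1-fold higher number from compound 2 to compound 1 (0.33 log units; beyond the scatter). On that basis compound 4 is estimated at 22000 nM in this assay, with a likely range from 11000 nM to 45000 nM. Among the measured compounds shown here, with only one earlier instance of the change, and measured on a different core, the range is kept wide, and a small chance remains that compound 4 falls beyond the working range of this assay.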

Compound 4, half-maximal inhibitory concentration: 3760 nM
For compound 4 the middle estimate is 5.9-fold (0.77 log units) above the measured one, outside the stated range (below it).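

In this assay, methyl in place of trifluoromethyl on an aromatic carbon gave a 2.8-fold lower number from compound 3 to compound 4 (0.45 log units; beyond the scatter), so the step did not carry over from one core to the other and instead changed direction: the same change on two cores in this assay, a 2.1-fold higher number (0.33 log units; beyond the scatter) from compound 2 to compound 1 and a 2.8-fold lower number (0.45 log units; beyond the scatter) from compound 3 to compound 4, 6.0-fold (0.78 log units) apart, beyond the scatter of two such steps

For this series, then, the effect of this change on one core is no reliable guide to its effect on the other, and the preference between the two groups depends on which core carries them. Among these compounds, the result does not show why the direction differs, since each core contributes only one matched pair and no property of either group or core was measured, nor does it show whether the reversal would extend to other changes at this place or is specific to methyl and trifluoromethyl.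

The compounds shown leave open whether a chlorine or a nitrile at the same place on the ring would follow the order seen on the core of compound 1 or the order seen on the core of compound 3. They also leave open whether a third core, for instance one carrying an amine, would side with either.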